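A few compounds are considered here, and "the series" means these few. Any claim that something is new, unique, unknown or untested is made for them only; others in the source may bear on it.

Compound 1 `Cc1cccc(-n2nncc2CN2C(=O)C3(C(C#N)=C(N)Oc4c(N)cc5nc6ccccc6nc5c43)c3ccccc32)c1`, compound 2 `N#CC1=C(N)Oc2c(N)cc3nc4ccccc4nc3c2C12C(=O)N(Cc1cnnn1-c1ccc([N+](=O)[O-])cc1[N+](=O)[O-])c1ccccc12` and compound 3 `N#CC1=C(N)Oc2c(N)cc3nc4ccccc4nc3c2C12C(=O)N(Cc1cnnn1-c1ccc(Cl)cc1[N+](=O)[O-])c1ccccc12` share one core and differ only in the aryl group on an aromatic nitrogen. In a functional assay on HCT-116 cells (Homo sapiens) for antiproliferative activity, read by MTT assay, with a stated time of 48 h (on this read-out lower numbers stand for stronger inhibition and higher numbers for weaker inhibition), compound 1 gives only a limit of the assay, > 50000 nM (the limit of > 50000 nM in this assay, at which 1 of the 3 values shown sits). Compound 2, carrying a 2,4-dinitrophenyl, gives 23900 nM in this assay, and compound 3, carrying a 4-chloro-2-nitrophenyl, gives 28700 nM. The step of an at least 2.0-fold lower number from compound 1 to compound 2 (0.32 log units; beyond the scatter) is clear, the step of an at least 1.7-fold lower number from compound 1 to compound 3 (0.24 log units; that floor lies within the scatter) is not, and the step of a 1.2-fold higher number from compound 2 to compound 3 (0.08 log units; within the scatter) is small. Compound 3 thus holds the higher of the two measured numbers, with compound 2 nearest and within the scatter of it.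

Compound 4 `Cc1cc(C)c(-n2nncc2CN2C(=O)C3(C(C#N)=C(N)Oc4c(N)cc5nc6ccccc6nc5c43)c3ccccc32)c(C)c1` differs from compound 3 by 2,4,6-trimethylphenyl in place of 4-chloro-2-nitrophenyl on an aromatic nitrogen. The measured steps that bear on this change are an at least 1.7-fold lower number from compound 1 to compound 3 (0.24 log units; that floor lies within the scatter) and an at least 2.0-fold lower number from compound 1 to compound 2 (0.32 log units; beyond the scatter), which both moved the number down when a nitro-bearing aryl took the place of a methyl-bearing phenyl. Compound 4 returns to a methyl-substituted phenyl, so the step of a 1.7-fold higher number from compound 3 to compound 4 (0.24 log units; within the scatter) is expected to run in the opposite direction, back toward the limit seen for compound 1. Compound 4 is therefore expected to give about 50000 nM in this assay, within a range of 20000 nM to 150000 nM, and may again be reported only as a limit.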

Compound 4, half-maximal inhibitory concentration: > 50000 nM
Compound 4: no number, only a limit; the forecaster's own chance of this, stated with the estimate: 55%; the middle value sits exactly at the limit.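

Compound 4 shows that a second methyl-bearing phenyl on this aromatic nitrogen, here 2,4,6-trimethylphenyl, also ends at a limit rather than a number, so the limit is not peculiar to the 3-methylphenyl of compound 1 in this assay: the limit of > 50000 nM in this assay, at which 2 of the 4 values shown sit. Putting 2,4,6-trimethylphenyl in place of 2,4-dinitrophenyl gives an at least 2.0-fold higher number from compound 2 to compound 4 (0.32 log units; beyond the scatter), whereas putting it in place of 4-chloro-2-nitrophenyl gives an at least 1.7-fold higher number from compound 3 to compound 4 (0.24 log units; that floor lies within the scatter), so only the first of these separates the two kinds of aryl group firmly. The step from compound 1 to compound 4 cannot be read, as both ends of it are limits, and among these four compounds none goes against the split between nitro-bearing aryl groups with numbers and methyl-bearing ones with limits.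

The compounds shown leave open whether the nitro group itself goes with the measurable numbers, as every aryl group here that gives a number carries one and every aryl group at the limit carries methyl instead. On these data alone, a phenyl bearing only a chloro, a methoxy or an amine would test this, and it also remains open how the two methyl-bearing compounds compare with each other.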